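Amide versus urea linker on the shared core

The compounds below may be only part of what the source reports. "The series", "measured", "known", "first", "only" and "open" are said of these compounds alone.

Values in a functional assay on NCI-H23 cells (Homo sapiens) for inhibition, read by sulforhodamine B assay, with a stated time of 48 h (on this read-out higher numbers stand for weaker inhibition of growth and lower numbers for stronger inhibition of growth), for the three measured compounds:
Compound 1 `COc1cc(-c2nn(-c3cccc(NC(=O)c4cccc(C(F)(F)F)c4)c3)cc2-c2ccncc2)ccc1Cl`: 32500 nM
Compound 2 `O=C(Nc1cccc(-n2cc(-c3ccncc3)c(-c3ccc(Cl)c(O)c3)n2)c1)Nc1cc(C(F)(F)F)cc(C(F)(F)F)c1`: 3270 nM
Compound 3 `COc1cc(-c2nn(-c3cccc(NC(=O)Nc4cccc(C(F)(F)F)c4)c3)cc2-c2ccncc2)ccc1Cl`: 3410 nM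

Compound 3 stands second highest of the three numbers; its value and that of compound 2 lie within the scatter of each other, while compound 1 sits well above it. Compound 4 `COc1cc(-c2nn(-c3cccc(NC(=O)c4ccccc4)c3)cc2-c2ccncc2)ccc1Cl` differs from compound 3 by phenyl in place of (3-(trifluoromethyl)phenyl)amino on a carbonyl carbon. Going by the values given here, the only measured step that bears on this is a 9.5-fold lower number from compound 1 to compound 3 (0.98 log units; beyond the scatter), which runs in the opposite direction; compound 4 reverses that change and also removes the trifluoromethyl, for which no measured pair exists. The number for compound 4 is therefore expected to move back toward the upper end of the set, meaning an 8.8-fold higher number from compound 3 to compound 4 (0.94 log units; beyond the scatter) in this assay. The estimate for compound 4 is 30000 nM, with a range from 8000 nM to 100000 nM.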

Compound 4, concentration for total growth inhibition: > 100000 nM
Compound 4: only a limit was reported; the forecaster's own chance of this, stated with the estimate: 12%; middle value at least 3.3-fold (0.52 log units) from the limit.
By their numbers in this assay, from the lowest: compounds 2 and 3 (each within the scatter of the next); then compound 1. At a limit, above all of these: compound 4.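

In this assay compound 4 gives only a limit of the assay, not a number: the limit of > 100000 nM in this assay, at which 1 of the 4 values shown sits. The trifluoromethyl also matters on the amide: hydrogen in its place gives an at least 3.0-fold higher number from compound 1 to compound 4 (0.48 log units; beyond the scatter). Phenyl in place of (3-(trifluoromethyl)phenyl)amino gives an at least 29-fold higher number from compound 3 to compound 4 (1.46 log units; beyond the scatter), so loss of the urea nitrogen and the trifluoromethyl together costs more than the amide-urea change alone, and both new steps are lower bounds.

Open, going by these compounds, is how a urea bearing an unsubstituted phenyl would read. Also open, on these data alone, is whether a nitrile or an amine in place of trifluoromethyl would restore growth inhibition.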